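From the fluoro chain to a branched hydroxymethyl chain

The compounds below may be only part of what the source reports. "The series", "measured", "known", "first", "only" and "open" are said of these compounds alone.

Of the compounds shown here, two have been read in a functional assay on HL-60 cells (Homo sapiens) for cytotoxicity, read by WST assay, with a stated time of 48 h; a higher number here means a weaker inhibitor, a lower number a stronger inhibitor. Compound 1 (`COc1cc(C(c2ccc(O)c(OC)c2)[C@H](C)[C@H](C)CO)ccc1O`) gives > 100000 nM, which is a limit and not a number. Compound 1 thus stands at the limit of > 100000 nM in this assay, at which 1 of the 2 values shown sits. Among the compounds with values here, compound 2 (`COc1cc(C(c2ccc(O)c(OC)c2)[C@H](C)[C@H](C)CF)ccc1O`) gives 56000 nM, the only true number so far, so its standing rests on a single comparison.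

Compound 3 (`COc1cc(C(c2ccc(O)c(OC)c2)[C@H](CO)C(C)C)ccc1O`) differs from compound 2 on a saturated chain carbon bound to two aromatic carbons: 1-(hydroxymethyl)-2-methylpropyl in place of 2-(fluoromethyl)-1-methylpropyl on a saturated chain carbon bound to two aromatic carbons. Within the data shown here, a hydroxy group returns in compound 3, so the one measured step that bears on it is an at least 1.7-fold lower number from compound 1 to compound 2 (0.25 log units; that floor lies within the scatter), read here in reverse. Among the measured compounds shown here, no measured step covers the exchange of 2-(fluoromethyl)-1-methylpropyl for 1-(hydroxymethyl)-2-methylpropyl as a whole. A small move towards a higher number is therefore expected in this assay, and the reading may well stop at the limit.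

The expected step is a 1.6-fold higher number from compound 2 to compound 3 (0.21 log units; within the scatter). For compound 3 the estimated value is 90000 nM, with an expected range of 40000 nM to 200000 nM.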

Compound 3, half-maximal inhibitory concentration: > 100000 nM
Compound 3 was reported as a limit; the forecaster's own chance of this, stated with the estimate: 50%; middle value at least 1.1-fold (0.04 log units) away from the limit.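

In this assay compound 3 gives > 100000 nM, which is a limit and not a number, so the 1-(hydroxymethyl)-2-methylpropyl chain on the saturated chain carbon bound to two aromatic carbons yields no readable value, as the 2-(hydroxymethyl)-1-methylpropyl chain of compound 1 did. Within the data shown here, the exchange of 2-(fluoromethyl)-1-methylpropyl for 1-(hydroxymethyl)-2-methylpropyl gives an at least 1.7-fold higher number from compound 2 to compound 3 (0.25 log units; that floor lies within the scatter), so compound 2 remains the only compound with a true number, and the floor of this step does not separate the two compounds. The step between the two hydroxymethyl chains of compound 1 and compound 3 cannot be read, and the series now stands as follows: the limit of > 100000 nM in this assay, at which 2 of the 3 values shown sit.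

Compound 3 differs from compound 2 in both the terminal group and the branching of the chain, so the compounds shown do not separate the two changes; a 1-(fluoromethyl)-2-methylpropyl chain would bear directly on that question. As far as these compounds go, how an aminomethyl group or a carboxylic acid at the end of the chain, or a longer chain, would read in this assay also stays open.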